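The source may hold more compounds than are shown below. What is called first, only, known or untested is meant among the compounds shown, and "the series" means these compounds.

Of the compounds shown here, two have been measured in an assay on CHO cells for displacement of a labelled ligand from adenosine receptor A1 (Homo sapiens) (a lower number here means a stronger inhibitor, a higher number a weaker inhibitor), so far. Compound 1 `COc1ccc(CNc2ncc(C(=O)O)c3nc(-c4ccco4)nn23)cc1OC` carries a carboxy group and gives 958 nM. Compound 2 `CNC(=O)c1cnc(NC(=O)NC2CCCCC2)n2nc(-c3ccco3)nc12` carries a methylcarbamoyl group instead and a urea side chain; in this assay compound 2 gives 8990 nM, the higher of the two numbers. Compound 3 `O=C(Nc1ncc(C(=O)O)c2nc(-c3ccco3)nn12)NC1CCCCC1` keeps the urea of compound 2 but has hydroxy in place of methylamino on a carbonyl carbon. Compound 3 is expected to give a lower number, because the carboxy-bearing compound 1 reaches 958 nM; the expected step is a 3.6-fold lower number from compound 2 to compound 3 (0.56 log units; beyond the scatter). The estimate for compound 3 is 2500 nM, in a range from 600 nM to 9000 nM.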

Compound 3, inhibition constant: > 100000 nM
Compound 3: only a limit was reported; the forecaster's own chance of this, stated with the estimate: 5%; middle value at least 40-fold (1.60 log units) from the limit.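

In this assay, hydroxy in place of methylamino on a carbonyl carbon, with the urea kept, gives an at least 11-fold higher number from compound 2 to compound 3 (1.04 log units; beyond the scatter). Compound 3 has only a limit, so the step is a minimum: the limit of > 100000 nM in this assay, at which 1 of the 3 values shown sits.

Compound 1 also carries a carboxy group and gives 958 nM, so a carboxy group at this place does not by itself rule out a measurable number.

From the compounds shown here alone, whether a methyl ester or an unsubstituted amide on this carbonyl carbon would stay near compound 2 remains open. So does how methylcarbamoyl behaves with the side chain of compound 1.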